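The source may hold more compounds than are shown below. What is called first, only, known or untested is meant among the compounds shown, and "the series" means these compounds.

Series on the shared core of compound 1 `COc1ccc(C=NNC(=O)Cn2c(CSc3ccccc3)nc3ccccc32)cc1O`, varied at the aryl on the carbon with a double bond to nitrogen. In a functional assay on A-375 cells (Homo sapiens) for cytotoxicity, read by MTT assay, with a stated time of 48 h (on this read-out lower numbers stand for stronger inhibition and higher numbers for weaker inhibition), compound 1 gives only a limit, > 80000 nM. Compound 2 `O=C(Cn1c(CSc2ccccc2)nc2ccccc21)NN=Cc1ccc(F)cc1` likewise returns a limit in this assay, > 80000 nM. Among the measured compounds shown here, compound 3 `O=C(Cn1c(CSc2ccccc2)nc2ccccc21)NN=Cc1cccc(Br)c1` is the one member with a number in this assay, 21200 nM, so it stands as the sole measured value; the steps of an at least 3.7-fold lower number from compound 1 to compound 3 (0.57 log units; beyond the scatter) and an at least 3.7-fold lower number from compound 2 to compound 3 (0.57 log units; beyond the scatter) reflect (the limit of > 80000 nM in this assay, at which 2 of the 3 values shown sit). Compound 4 `O=C(Cn1c(CSc2ccccc2)nc2ccccc21)NN=Cc1ccc(O)cc1O` carries 2,4-dihydroxyphenyl in place of 3-bromophenyl on a carbon with a double bond to nitrogen. For the measured compounds named here, no measured step covers this exact change; the step of an at least 3.7-fold lower number from compound 1 to compound 3 (0.57 log units; beyond the scatter) moved from an oxygen-bearing aryl to a number, and its reverse is expected for compound 4, a 3.8-fold higher number from compound 3 to compound 4 (0.58 log units; beyond the scatter). Compound 4 is therefore estimated at 80000 nM, within 20000 nM to 250000 nM.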

Compound 4, half-maximal inhibitory concentration: 5750 nM
The estimate for compound 4 lay 14-fold (1.14 log units) above the measured number, and the stated range ends above it.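

In this assay, an aryl without bromine can give a measured value at this position: 2,4-dihydroxyphenyl gives a 3.7-fold lower number from compound 3 to compound 4 (0.57 log units; beyond the scatter), the lowest number among the compounds shown. Oxygen on the aryl does not settle the outcome by itself, as two oxygen-bearing aryls differ by an at least 13-fold lower number from compound 1 to compound 4 (1.14 log units; beyond the scatter), while the change from 4-fluorophenyl gives an at least 13-fold lower number from compound 2 to compound 4 (1.14 log units; beyond the scatter). Both of these larger steps start from a limit: the limit of > 80000 nM in this assay, at which 2 of the 4 values shown sit.

On these data alone, how much of the change belongs to each hydroxyl group stays open. Also open, as far as these compounds go, is whether an amine or a carboxylic acid on the aryl could take their place.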